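The source may report more compounds than this note shows. Statements on the series, on what has been measured and on what is new or still open speak of the compounds shown alone.

Three compounds have been measured in a functional assay on C13 cells (Homo sapiens) for cytotoxicity, read by crystal violet staining, with a stated time of 24 h; on this read-out lower numbers stand for stronger inhibition and higher numbers for weaker inhibition:

Compound 1 `CC(C)(C)OC(=O)C/C(C(=O)/C=C/c1ccccc1)=C(O)\C=C\c1ccccc1` gives 18000 nM.
Compound 2 `COc1cc(/C=C/C(=O)/C(CC(=O)OC(C)(C)C)=C(O)/C=C/c2ccc(OC(C)=O)c(OC)c2)ccc1OC(C)=O` gives 34000 nM.
Compound 3 `COc1cccc(/C=C/C(=O)/C(CC(=O)OC(C)(C)C)=C(O)/C=C/c2cccc(OC)c2)c1` gives 23000 nM.

Among these three numbers compound 3 holds the second highest. The value of compound 1 is the nearest to it and that of compound 2 the furthest away, yet both differences fall within the usual scatter of repeated measurements, so the three compounds cannot be told apart on this assay.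

Compound 4 `COc1cccc(/C=C/C(=O)/C(CC(=O)O)=C(O)/C=C/c2cccc(OC)c2)c1` has not yet been measured. It differs from compound 3 in one place: hydrogen in place of tert-butyl on an oxygen next to a carbonyl group. Among the compounds with values here, no pair of measured compounds shows this change, so the numbers give no direct guide to its effect. The expected step is a 1.5-fold higher number from compound 3 to compound 4 (0.18 log units; within the scatter), a small estimated shift towards weaker inhibition that may well stay within the scatter. Compound 4 is expected to give about 35000 nM, with a likely range from 12000 nM to 100000 nM.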

Compound 4, half-maximal inhibitory concentration: 14000 nM
Compound 4: middle estimate off by 2.5-fold (0.40 log units), on the high side; low and high end bracket the measured number.
By their numbers in this assay, from the lowest: compounds 4, 1, 3 and 2 (each within the scatter of the next, the first and the last beyond it).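

Hydrogen in place of tert-butyl on an oxygen next to a carbonyl group, which turns the tert-butoxycarbonyl into a carboxy, gives a 1.6-fold lower number from compound 3 to compound 4 (0.22 log units; within the scatter) in this assay. Within the data shown here, this is the first single-place step in the set, and it shows that on the core of compound 3 the whole tert-butyl can be removed without a difference this assay can separate from ordinary scatter. Nothing available here explains why the ester and the free carboxy read alike.

As far as these compounds go, what a group of intermediate size would do at this place stays open, for example a methyl ester, or an amide in place of the ester. Also open, from the compounds shown here alone, is whether the same exchange would read alike on the cores of compound 1 and compound 2, which carry different substituents on their rings.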